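A few compounds are considered here, and "the series" means these few. Any claim that something is new, unique, unknown or untested is made for them only; others in the source may bear on it.

Compound 2, with the structure `CCOC(=O)CCCCCOc1cccc(CN(C(=O)c2ccc(-c3cccc(-c4nnc(C)o4)c3)cc2)C(C)C)c1`, was tested in an ADME assay on HepG2 cells (Homo sapiens) for cytotoxicity, read by CellTiter-Glo and resazurin assay, with a stated time of 72 h (on this read-out lower numbers stand for an effect already at smaller amounts and higher numbers for an effect only at larger amounts of compound), and gave > 26000 nM, which is a limit of the assay and not a measured number. Its neighbour compound 1, with the structure `CCOC(=O)CCCCCOc1cccc(CN(C(=O)c2ccc(-c3cccc4ccccc34)cc2)C(C)C)c1`, also reached only a limit in this assay, > 26000 nM. For the measured compounds named here, the one measured step, a step that the two limits leave unreadable from compound 1 to compound 2, therefore cannot be sized, because both of its values rest at the limit of > 26000 nM in this assay, at which 2 of the 2 values shown sit. Compound 3 has the structure `CCOC(=O)CCCCCOc1cccc(CN(C(=O)c2ccc(-c3cccc(Cl)c3)cc2)C(C)C)c1` and differs from compound 2 in one place: chloro in place of 5-methyl-1,3,4-oxadiazol-2-yl on an aromatic carbon. Going by the values given here, no measured step speaks to this change, so the only guide is that every value shown so far lies at the limit. The step from compound 2 to compound 3 is expected to be a step that the limit leaves unreadable from compound 2 to compound 3, meaning no effect within the tested range. Compound 3 is therefore estimated in this assay at 30000 nM, with a range from 12000 nM to 90000 nM, most likely reported only as a limit again.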

Compound 3, half-maximal effective concentration: > 18400 nM
Compound 3 ended at the assay's limit (the forecaster's own chance of this, stated with the estimate: 80%); the middle value is on the limit's open side.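

Compound 1, compound 2 and compound 3 all ended at limits in this assay, so none of the steps among these three compounds can be read. The compounds shown leave open at what concentration, if any, each would harm these cells, and whether the changed group matters at all.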